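The source may report more compounds than this note shows. Statements on the series, on what has been measured and on what is new or still open speak of the compounds shown alone.

Measured in a functional assay on HCT-15 cells (Homo sapiens) for antiproliferative activity, read by sulforhodamine B assay (a higher number here means a weaker inhibitor of growth, a lower number a stronger inhibitor of growth), so far:
- compound 1 `CC(C)CCCOc1cccc(O)c1C(=O)/C=C/c1ccc(O)cc1` gives 11600 nM
- compound 2 `CC(C)(C)CCOc1cccc(O)c1C(=O)/C=C/c1ccc(C(=O)O)cc1` gives 2170 nM

With only these two numbers to compare, compound 1 stands higher, so it is the weaker growth inhibitor of the pair, and the gap to compound 2 lies beyond the usual scatter. The two compounds differ in more than one place, so their values alone do not show what any single change does.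

Compound 3 `CCCCCCOc1cccc(O)c1C(=O)/C=C/c1ccc(O)cc1` has not yet been measured in this assay. It has the same atoms as compound 1, joined differently: propyl in place of isopropyl on a saturated chain carbon, three bonds along the chain from an oxygen on an aromatic ring. In words, propyl replaces isopropyl on a saturated chain carbon, three bonds along the chain from an oxygen on an aromatic ring. Cut one bond further out, the same difference reads 4-methylpentyl to hexyl.

For the measured compounds named here, no measured pair shows the size of such a step, so the expectation is modest and has no firm direction. The expected change, a 1.2-fold lower number from compound 1 to compound 3 (0.06 log units; within the scatter), is estimated to stay within the scatter. The estimate for compound 3 is 10000 nM, with an expected range from 4500 nM to 22000 nM.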

Compound 3, concentration for 50% growth inhibition: > 30000 nM
Compound 3 gave a limit, no number; the forecaster's own chance of this, stated with the estimate: 7%; middle value at least 3.0-fold (0.47 log units) away from the limit.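

In this assay compound 3 gives > 30000 nM, which is a limit of the assay and not a number. The 4-methylpentyl chain of compound 1 and the hexyl chain of compound 3 hold the same atoms, yet changing isopropyl to propyl on a saturated chain carbon, three bonds along the chain from an oxygen on an aromatic ring, gives an at least 2.5-fold higher number from compound 1 to compound 3 (0.41 log units; beyond the scatter), so growth inhibition at this position depends on how the chain is joined and not only on which atoms it holds. The true size of this step remains unknown, and only its lower bound can be given because compound 3 sits at a limit: the limit of > 30000 nM in this assay, at which 1 of the 3 values shown sits.

The compounds shown leave open whether the branch must sit at this exact place on the chain, as isopentyl or a chain ending in a cyclohexyl ring would help to test. Compound 2 differs from compound 1 and compound 3 in more than one place, so they also leave open whether its carboxylic acid would change how much this chain change matters.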